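(3-Fluorophenyl)carbamoyl in Place of Ethyl on an Aromatic Oxygen

The source may report more compounds than this note shows. Statements on the series, on what has been measured and on what is new or still open speak of the compounds shown alone.

Compound 1, `CCOc1cc(=O)n(CCCO)c2c1CC(CC=C(C)C)C(C)(C)C2`, in a functional assay on PANC-1 cells (Homo sapiens) for inhibition, read by MTT assay, with a stated time of 24 h, tested at 10 uM (a lower number here means less inhibition, a higher number more inhibition at the concentration tested (going by the name of the read-out)), gives 16.6%.
Compound 2, `CCOc1cc(=O)n(CCCO)c2c1CC(C/C=C(\C)CCC=C(C)C)C(C)(C)C2`, in this assay gives 0.8%.
Compound 3, `CC(C)=CCC/C(C)=C/CC1Cc2c(OCCCNS(=O)(=O)c3ccc(Br)cc3)cc(=O)n(CCCO)c2CC1(C)C`, in this assay gives 0%.

Compound 2 stands second highest of the three numbers; its nearest neighbour is compound 3, within the scatter, and its furthest is compound 1, beyond the scatter. Compound 4, `CC(C)=CCC/C(C)=C/CC1Cc2c(OC(=O)Nc3cccc(F)c3)cc(=O)n(CCCO)c2CC1(C)C`, is not yet measured. It differs from compound 2 in one place: (3-fluorophenyl)carbamoyl in place of ethyl on an oxygen on an aromatic ring.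

Within the data shown here, no measured step touches the substituent on the aromatic oxygen itself. The step of a number 15.8 percentage points lower from compound 1 to compound 2 (beyond the scatter) changed the chain on the saturated ring and lowered the number modestly; the step of a number 0.8 percentage points lower from compound 2 to compound 3 (within the scatter) added a large group two bonds along the chain from that oxygen and stayed within the scatter. The closest analogy is therefore the second one, where a sizeable addition near the oxygen left the number essentially unchanged. On that basis no step beyond the scatter is expected for this assay from compound 2 to compound 4, so the expected step is a number 2.2 percentage points higher from compound 2 to compound 4 (within the scatter). Compound 4 is estimated at 3%, within a range from 0% to 14%.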

Compound 4, a percentage reported as inhibition, at one concentration (the size of the read-out at that concentration, not a potency): 0%
Compound 4: the middle estimate sits 3 percentage points above what was measured; the range from low to high includes it.
By their numbers in this assay, from the lowest: compounds 3, 4 and 2 (each within the scatter of the next); then compound 1.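

Among these compounds, replacing ethyl with (3-fluorophenyl)carbamoyl on the oxygen on the aromatic ring gives a number 0.8 percentage points lower from compound 2 to compound 4 (within the scatter) in this assay, and this is the first measured change made directly on that oxygen. Among the compounds shown here, the entering group brings an aromatic ring of carbon only, a hydrogen-bond donor and a hydrogen-bond acceptor that ethyl lacks, yet at the single concentration tested the exchange brings no gain in inhibition, though compound 2, at 0.8%, leaves the read-out little room to show a loss. No measurement shown here offers an explanation for this outcome.

As far as these compounds go, whether the same exchange would behave alike on the shorter chain of compound 1, which gives 16.6%, remains open, since there the number has room to move in either direction. Also open, from the compounds shown here alone, is how an acetyl group, a free hydroxyl or a chain ending in an amine on that oxygen would read, and whether the fluorine on the phenyl ring matters at all.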